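This account rests on a few compounds, and the source may have more. Where it says the series, first, only, none or still open, it means among the compounds named here.

Within the data shown here, compound 1 `O=C(CN1CCN(c2nnc(Cc3ccncc3)c3ccccc23)CC1)Nc1ccc(F)c(Cl)c1` is one of two compounds measured in a functional assay on HT-29 cells (Homo sapiens) for cytotoxicity, read by MTT assay, with a stated time of 72 h; on this read-out lower numbers stand for stronger inhibition and higher numbers for weaker inhibition. In this assay compound 1 gives 880 nM, the lowest of the two numbers. Compound 2 `Cc1ccc(F)cc1NC(=O)CN1CCN(c2nnc(Cc3ccccc3)c3ccccc23)CC1` differs from compound 1 in several places. In this assay compound 2 gives 171000 nM. Compound 3 `Cc1ccc(NC(=O)CN2CCN(c3nnc(Cc4ccncc4)c4ccccc34)CC2)c(C)c1` has not yet been measured. It differs from compound 1 in one place: 2,4-dimethylphenyl in place of 3-chloro-4-fluorophenyl on an amide-type nitrogen. Among the measured compounds shown here, no single-change step between measured compounds is available as a guide, so the direction rests on the change alone. The number for compound 3 is expected to rise, with a step of roughly a 6.8-fold higher number from compound 1 to compound 3 (0.83 log units; beyond the scatter). Compound 3 is estimated at 6000 nM, within a range of 1500 nM to 30000 nM.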

Compound 3, half-maximal inhibitory concentration: 1930 nM
The estimate for compound 3 lay 3.1-fold (0.49 log units) above the measured number, within the range that was stated.
By their numbers in this assay, from the lowest: compound 1; then compound 3; then compound 2.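

Among these compounds, this gives the first single-change reading at this position: on the amide-type nitrogen, 2,4-dimethylphenyl in place of 3-chloro-4-fluorophenyl gives a 2.2-fold higher number from compound 1 to compound 3 (0.34 log units; beyond the scatter) in this assay. The ring on this nitrogen therefore affects the number, but this exchange of one ring for another with the same heavy-atom count moves it only modestly. No measurement shown explains the step.

This single pair cannot separate the contribution of the chlorine and fluorine from that of the two methyl groups. It also leaves open how a phenyl ring carrying an amine or a carboxylic acid would behave here.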